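Ester in Place of Amide: One Change Weighed

The compounds below may be only part of what the source reports. "The series", "measured", "known", "first", "only" and "open" are said of these compounds alone.

Of the compounds shown here, two have been measured in a functional assay on SK-MEL-2 cells (Homo sapiens) for antiproliferative activity; a higher number here means a weaker inhibitor of growth, a lower number a stronger inhibitor of growth. Compound 1 `CCOC(=O)C[C@H]1[C@@H](O[Si](C)(C)C(C)(C)C)[C@H](n2cnc3c(NC(=O)Nc4ccccc4)ncnc32)O[C@@H]1COC(=O)NC` gives 13.2 nM. Compound 2 `CNC(=O)NC[C@H]1O[C@@H](n2cnc3c(NC(=O)Nc4ccccc4)ncnc32)[C@H](O[Si](C)(C)C(C)(C)C)[C@@H]1CC(=O)N(C)OC` gives 14.9 nM, which is the higher of the two numbers, though the gap to compound 1 lies within the scatter. Compound 3 `CCOC(=O)C[C@H]1[C@@H](O[Si](C)(C)C(C)(C)C)[C@H](n2cnc3c(NC(=O)Nc4ccccc4)ncnc32)O[C@@H]1CNC(=O)NC` has not yet been measured. It differs from compound 2 at one spot: ethoxy in place of methoxy(methyl)amino on a carbonyl carbon. Within the data shown here, no measured pair shows a change of this kind, so the expected step of a 1.1-fold lower number from compound 2 to compound 3 (0.03 log units; within the scatter) is modest, with no direction favoured beyond the scatter. Compound 3 is therefore estimated at 14 nM, within 6 nM to 35 nM.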

Compound 3, concentration for 50% growth inhibition: 5.42 nM
The estimate for compound 3 lay 2.6-fold (0.41 log units) above the measured number; measured number below the stated range.
By their numbers in this assay, from the lowest: compound 3; then compounds 1 and 2 (each within the scatter of the next).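

Ethoxy in place of methoxy(methyl)amino on a carbonyl carbon is not a silent change: it gives a 2.7-fold lower number from compound 2 to compound 3 (0.44 log units; beyond the scatter) in this assay and so moves the number beyond the scatter. With a 2.4-fold lower number from compound 1 to compound 3 (0.39 log units; beyond the scatter) in this assay the change to (methylcarbamoyl)amino from (methylcarbamoyl)oxy on a saturated chain carbon bound to a saturated ring carbon also counts. No measurement here explains either step.

Still open, as far as these compounds go, is how a carboxylic acid, a primary amide or a longer chain such as propoxy on that carbonyl carbon would compare with ethoxy.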